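Cytotoxicity in a Carbamate Series: Estimating Compound 4

A few compounds are considered here, and "the series" means these few. Any claim that something is new, unique, unknown or untested is made for them only; others in the source may bear on it.

Of the compounds shown here, three sharing one core have been tested in an ADME assay on C8166 cells (Homo sapiens) for cytotoxicity, read by MTT assay, with a stated time of 3 days; on this read-out higher numbers stand for lower toxicity in this test and lower numbers for higher toxicity in this test. Compound 1 `CC(C)(NC(=O)OCc1ccccc1)c1nc(O)c(O)c(C(=O)N/N=C/c2ccc(F)cc2)n1` gives 378000 nM. Compound 2 `Cc1ccc(CNC(=O)c2nc(C(C)(C)NC(=O)OCc3ccccc3)nc(O)c2O)cc1` gives 234000 nM. Compound 3 `COCCNC(=O)c1nc(C(C)(C)NC(=O)OCc2ccccc2)nc(O)c1O` gives 348000 nM. Among these three numbers compound 3 stands second highest; its nearest neighbour is compound 1 and its furthest is compound 2, and both gaps fall within the scatter, so on this read-out the three compounds cannot be told apart.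

Compound 4 `CC(C)(NC(=O)OCc1ccccc1)c1nc(O)c(O)c(C(=O)NCc2ccc(C(F)(F)F)cc2)n1` has not yet been measured. It differs from compound 3 by 4-(trifluoromethyl)phenyl in place of methoxymethyl on a saturated chain carbon bound to an amide-type nitrogen. The steps already seen among the measured compounds all stayed small: a 1.5-fold higher number from compound 2 to compound 3 (0.17 log units; within the scatter), a 1.6-fold lower number from compound 1 to compound 2 (0.21 log units; within the scatter) and a 1.1-fold lower number from compound 1 to compound 3 (0.04 log units; within the scatter). Each of those swaps, whether a chain for an aromatic group or one aromatic group for another, left the number inside the scatter. The present change again trades a chain for an aromatic group, so no step beyond the scatter is expected in this assay, in either direction. The step expected is a 1.2-fold lower number from compound 3 to compound 4 (0.08 log units; within the scatter). Compound 4 is therefore estimated at 290000 nM, with a range from 150000 nM to 560000 nM.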

Compound 4, half-maximal cytotoxic concentration: 58100 nM
Beside the measured number, compound 4's estimate is 5.0-fold (0.70 log units) above it; the measured number lies below the stated range.
By their numbers in this assay, from the lowest: compound 4; then compounds 2, 3 and 1 (each within the scatter of the next).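

In this assay, the substituent on the saturated chain carbon bound to the amide-type nitrogen can clearly change the number: putting 4-(trifluoromethyl)phenyl in place of methoxymethyl gives a 6.0-fold lower number from compound 3 to compound 4 (0.78 log units; beyond the scatter), and the comparison with the hydrazone-type compound gives a 6.5-fold lower number from compound 1 to compound 4 (0.81 log units; beyond the scatter), with a lower number here meaning higher toxicity in this test. The closest comparison changes only trifluoromethyl in place of methyl on an aromatic carbon and still gives a 4.0-fold lower number from compound 2 to compound 4 (0.61 log units; beyond the scatter), so among these compounds an aromatic ring at this position does not by itself bring the number down, since compound 2 stayed within the scatter of compound 1 and compound 3. No measurement shown here explains why this one substitution has such an effect.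

On these data alone, with only methyl and trifluoromethyl compared on this benzyl ring, it remains open whether a chlorine atom, a methoxy group or a carboxylic acid in the same place would behave like methyl or like trifluoromethyl. As far as these compounds go, it is also open whether an amine or a longer chain on the amide-type nitrogen would keep the number near that of compound 3.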